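Cyclopropylidene methanol series, cytotoxicity on MOLT-3 cells

The source may hold more compounds than are shown below. What is called first, only, known or untested is meant among the compounds shown, and "the series" means these compounds.

Three compounds share one core: compound 1 `CC(C)CNc1nc(N)nc2c1ncn2/C=C1/CC1(CO)CO`, compound 2 `Nc1nc(OCC(F)(F)F)c2ncn(/C=C3/CC3(CO)CO)c2n1` and compound 3 `CC(C)Sc1nc(N)nc2c1ncn2/C=C1/CC1(CO)CO`. In an ADME assay on MOLT-3 cells (Homo sapiens) for cytotoxicity, with a stated time of 7 days (a lower number here means that less compound is tolerated, a higher number that more compound is tolerated), compound 1 has "not determined" (no result reported). In this assay compound 2 gives > 20000 nM, a limit of the assay. In this assay compound 3 likewise gives > 20000 nM, again a limit. Among the measured compounds shown here, the step that the two limits leave unreadable from compound 2 to compound 3 is therefore not readable, and the only evidence is the limit of > 20000 nM in this assay, at which 2 of the 3 values shown sit. Compound 4 `CNc1nc(N)nc2c1ncn2/C=C1/CC1(CO)CO` differs from compound 3 by methylamino in place of isopropylsulfanyl on an aromatic carbon. For the measured compounds named here, no measured step bears on this change, and no value reaches a number. Compound 4 is expected to give an estimated 30000 nM, most likely again only a limit, within 10000 nM to 100000 nM. The expected step that the limit leaves unreadable from compound 3 to compound 4 is thus essentially none beyond the scatter.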

Compound 4, half-maximal cytotoxic concentration: > 20000 nM
Compound 4: a limit, no number (the forecaster's own chance of this, stated with the estimate: 80%); the middle value is on the limit's open side.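

In this assay, among the compounds shown here, compound 4 gives > 20000 nM as a limit of the assay, so no step among compound 2, compound 3 and compound 4 can be read: the limit of > 20000 nM in this assay, at which 3 of the 4 values shown sit. The compounds shown leave open whether any change at this aromatic carbon brings the half-maximal cytotoxic concentration to a readable number.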